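Shortening the ether chain on a shared quinoline-free core

The source may hold more compounds than are shown below. What is called first, only, known or untested is meant among the compounds shown, and "the series" means these compounds.

Of the compounds shown here, three built on one shared core have been tested in a functional assay on A549 cells (Homo sapiens) for cytotoxicity; on this read-out lower numbers stand for an effect already at smaller amounts and higher numbers for an effect only at larger amounts of compound. Compound 1 `CC(C)COc1cc(-c2ccccc2)nc2ccccc12` carries an isobutyl group on the ring oxygen. In this assay compound 1 gives > 10 ug/mL, which is a limit of the assay and not a number. Compound 2 `Oc1cc(-c2ccccc2)nc2cc(F)ccc12` carries a free hydroxyl and a fluorine on its core, and in this assay compound 2 gives 0.96 ug/mL. Compound 3 `CC(C)Oc1cc(-c2ccccc2)nc2ccccc12` carries an isopropyl group on the ring oxygen. In this assay compound 3 gives > 10 ug/mL, again a limit rather than a number. Compound 1 and compound 3 both rest at the limit of > 10 ug/mL in this assay, at which 2 of the 3 values shown sit, so the step that the two limits leave unreadable from compound 1 to compound 3 cannot be read in either direction or size. Compound 3 therefore stands only at a limit, and one of the two other values shown is a limit as well.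

Compound 4 `CCOc1cc(-c2ccccc2)nc2ccccc12` differs from compound 3 by hydrogen in place of methyl on a saturated chain carbon bound to an oxygen on an aromatic ring and a saturated chain carbon. Within the data shown here, the only measured step that touches this kind of change is the one from isobutyl to isopropyl, and it is unreadable. With both alkyl ethers at the limit, no step beyond the scatter is expected, and the step that the limit leaves unreadable from compound 3 to compound 4 is my estimate. Compound 4 is expected to give about 12 ug/mL, within a range from 4 ug/mL to 40 ug/mL.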

Compound 4, half-maximal effective concentration: > 10 ug/mL
Compound 4: a limit, no number (the forecaster's own chance of this, stated with the estimate: 65%); the middle value does not contradict the limit.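

Compound 4 sits at the same limit of the assay as compound 1 and compound 3, so no step among these three can be read in this assay: the limit of > 10 ug/mL in this assay, at which 3 of the 4 values shown sit.

The compounds shown leave open how the three ethers relate to compound 2, which differs from them in more than one place, and whether its free hydroxyl or its fluorine goes with its measured value.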